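The compounds below may be only part of what the source reports. "The series", "measured", "known", "first", "only" and "open" are said of these compounds alone.

Working notes on the series, read in a functional assay on HT-29 cells (Homo sapiens) for antiproliferative activity, read by MTT assay, with a stated time of 48 h; a lower number here means a stronger inhibitor, a higher number a weaker inhibitor. In this assay compound 3 (`Cc1ccc2nc(-c3ccc(Cl)cc3)cc(COCc3ccccc3)c2c1`) gives > 100000 nM, which is a limit and not a number. Compound 1 (`Cc1ccc2nc(-c3ccc(Cl)cc3)cc(C(=O)OCc3ccccc3)c2c1`) gives > 100000 nM, also a limit. The series therefore has (the limit of > 100000 nM in this assay, at which 2 of the 3 values shown sit), and compound 3 has no measured number to start from. Going by the values given here, the only number so far belongs to compound 2 (`COc1ccc(-c2cc(C(=O)OCc3ccccc3)c3cc(C)ccc3n2)cc1`), at 17300 nM.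

Compound 4 (`COc1ccc(-c2cc(COCc3ccccc3)c3cc(C)ccc3n2)cc1`) follows from compound 3 through methoxy in place of chloro on an aromatic carbon, para to a large group, or 4-chlorophenyl to 4-methoxyphenyl. The same change has been measured once, elsewhere in the series, and gave an at least 5.7-fold lower number from compound 1 to compound 2 (0.76 log units; beyond the scatter). From the compounds shown here alone, that step lies beyond the scatter, but it starts from a limit, so its full size is unknown. It is also a single pair with a different remainder of the molecule, so its transfer to compound 3 remains an expectation.

A step of similar kind, towards a lower number, is therefore expected in this assay. The expected step is an at least 4.5-fold lower number from compound 3 to compound 4 (0.65 log units; beyond the scatter). Compound 4 is estimated at 22000 nM, with an expected range of 7000 nM to 70000 nM.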

Compound 4, half-maximal inhibitory concentration: > 100000 nM
Compound 4: a limit, no number; the forecaster's own chance of this, stated with the estimate: 25%; middle value at least 4.5-fold (0.65 log units) away from the limit.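

In this assay, compound 3 and compound 4 each give only a limit and not a number, so no step can be read between them. The series now stands largely at that limit: the limit of > 100000 nM in this assay, at which 3 of the 4 values shown sit. The compounds shown leave open whether methoxy in place of chloro lowers the number at all on the remainder shared by compound 3 and compound 4.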